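Methyl to Trifluoromethyl Repeated on a Second Core

A few compounds are considered here, and "the series" means these few. Any claim that something is new, unique, unknown or untested is made for them only; others in the source may bear on it.

Compound 2 `C=C1C(=O)[C@]23C[C@@]1(O)CC[C@H]2c1ccc(O)c(C)c1[C@@H]3Cn1cc(-c2ccc(C)cc2)nn1` and compound 1 `C=C1C(=O)[C@]23C[C@@]1(O)CC[C@H]2c1ccc(O)c(C)c1[C@@H]3Cn1cc(-c2ccc(C(F)(F)F)cc2)nn1` share one core and differ in a single place: trifluoromethyl in place of methyl on an aromatic carbon. In a functional assay on MCF7 cells (Homo sapiens) for cytotoxicity, read by MTT assay, with a stated time of 4 days (on this read-out higher numbers stand for weaker inhibition and lower numbers for stronger inhibition), compound 2 gives 370 nM, while compound 1 gives 1840 nM; this is a 5.0-fold higher number from compound 2 to compound 1 (0.70 log units; beyond the scatter). Compound 3 `Cc1ccc(-c2cn(C[C@H]3c4c(ccc(OS(=O)(=O)c5ccc(C)cc5)c4C)[C@@H]4CC[C@@]5(C)C[C@]43CC5=O)nn2)cc1` is built on a different core, and the difference between the two cores is not broken down here. In this assay compound 3 reaches only a limit of the assay, > 20000 nM. That reading is described as the limit of > 20000 nM in this assay, at which 1 of the 3 values shown sits. Compound 4 `Cc1ccc(S(=O)(=O)Oc2ccc3c(c2C)[C@H](Cn2cc(-c4ccc(C(F)(F)F)cc4)nn2)[C@@]24CC(=O)[C@@](C)(CC[C@@H]32)C4)cc1` has not yet been measured and differs from compound 3 by the same change as before: trifluoromethyl in place of methyl on an aromatic carbon. On the first core this change weakened inhibition, as the step of a 5.0-fold higher number from compound 2 to compound 1 (0.70 log units; beyond the scatter) shows, and compound 3 already sits at the limit, so compound 4 is expected to stay at or past that limit, with an expected step that the limit leaves unreadable from compound 3 to compound 4. The estimate for compound 4 in this assay is 50000 nM, with a likely span from 15000 nM to 200000 nM.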

Compound 4, half-maximal inhibitory concentration: > 20000 nM
Compound 4 gave a limit, no number; the forecaster's own chance of this, stated with the estimate: 90%; the middle value does not contradict the limit.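

In this assay, within the data shown here, compound 3 and compound 4 each reach only a limit of the assay, not a number, so no step between them can be read: the limit of > 20000 nM in this assay, at which 2 of the 4 values shown sit. The compounds shown leave open whether trifluoromethyl in place of methyl weakens inhibition on the core of compound 3 as it does on the core of compound 1.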